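The source may report more compounds than this note shows. Statements on the series, on what has been measured and on what is new or still open speak of the compounds shown alone.

Values in a functional assay on HCT-116 cells (Homo sapiens) for antiproliferative activity (a higher number here means a weaker inhibitor, a lower number a stronger inhibitor), for the series so far
compound 1 `Cc1c2c(n3c1CCN(C)C[C@@H](C)[C@H](C)Nc1cc-3ccc1C(N)=O)CC(C)(C)CC2=O` gives 27 nM
compound 2 `CC(=O)N1CCCc2c(C)c3c(n2-c2ccc(C(N)=O)c(c2)N[C@@H](C)[C@@H]1C)CC(C)(C)CC3=O` gives 27 nM
compound 3 `Cc1c2c(n3c1CCCN(C(=O)CO)[C@@H](C)[C@H](C)Nc1cc-3ccc1C(N)=O)CC(C)(C)CC2=O` gives 51 nM

Compound 1 and compound 2 show the same number, and compound 3 lies within the scatter of both. The next compound to consider is compound 4 `CC[C@H](N)C(=O)N1CCc2c(C)c3c(n2-c2ccc(C(N)=O)c(c2)N[C@@H](C)[C@H](C)C1)CC(C)(C)CC3=O`, which departs from compound 1 with (1-aminopropyl)carbonyl in place of methyl on an amine nitrogen in a ring. The counted difference is (1-aminopropyl)carbonyl in place of methyl on an amine nitrogen in a ring.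

For the measured compounds named here, only one measured step bears on this change. The step of a 1.9-fold higher number from compound 2 to compound 3 (0.28 log units; within the scatter) swaps hydroxy in for hydrogen on a saturated chain carbon bound to a carbonyl carbon, and it stays within the scatter. Both of these compounds carry a carbonyl group on a ring nitrogen, yet their numbers stay close to that of compound 1, which has methyl on its ring nitrogen. Going by the values given here, no measured step goes from methyl to a carbonyl group on the same nitrogen, and no measured compound has an amine on such a chain. The evidence is therefore thin, and the range is kept wide.

In this assay no change beyond the scatter is expected, and the estimated step is a 1.3-fold higher number from compound 1 to compound 4 (0.11 log units; within the scatter) in size. Compound 4 is expected at 35 nM, with an estimated range of 10 nM to 120 nM.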

Compound 4, half-maximal inhibitory concentration: 33 nM
The estimate for compound 4 lay 1.1-fold (0.03 log units) above the measured number; low and high end bracket the measured number.
By their numbers in this assay, from the lowest: compounds 1, 2, 4 and 3 (each within the scatter of the next).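

At the amine nitrogen in a ring, this assay now gives a direct reading of the change from methyl to (1-aminopropyl)carbonyl, with a 1.2-fold higher number from compound 1 to compound 4 (0.09 log units; within the scatter) as the result. The earlier compounds shown here offered no step from methyl to a carbonyl group on this nitrogen, whereas this pair shows that a group of 6 heavy atoms, with 1 hydrogen-bond donor, 2 hydrogen-bond acceptors and 1 defined stereocentre, can replace a single carbon without a change beyond the scatter; this holds for this one pair and this one read-out, and does not yet make a pattern across the series. Nothing available accounts for this outcome.

Still open, on these data alone, is whether the amine on the chain plays any part in the reading, which a plain propanoyl group or a carboxylic acid in place of the amine on the same nitrogen would address. Also open, as far as these compounds go, are the opposite configuration at the defined stereocentre of the chain and a longer chain ending in an amine, either of which could show how far this nitrogen continues to accept larger groups.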